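This account rests on a few compounds, and the source may have more. Where it says the series, first, only, none or still open, it means among the compounds named here.

Series in a functional assay on A549 cells (Homo sapiens) for cytotoxicity, read by MTT assay, with a stated time of 48 h; on this read-out lower numbers stand for stronger inhibition and higher numbers for weaker inhibition:
- compound 1 `COc1ccc(-n2cc(CCCOS(=O)(=O)c3ccc(C)cc3)nn2)cc1`: 74600 nM
- compound 2 `Cc1ccc(S(=O)(=O)OCCCc2cn(-c3cccc(C#N)c3)nn2)cc1`: > 100000 nM, a limit
- compound 3 `COC(=O)c1ccc(-n2cc(CCCOS(=O)(=O)c3ccc(-c4ccccc4)cc3)nn2)cc1`: "not determined" (no result reported)

For the measured compounds named here, compound 1 holds the only actual number, at 74600 nM. The entry for compound 2 is a limit, not a number: the limit of > 100000 nM in this assay, at which 1 of the 3 values shown sits.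

Next is compound 4 `Cc1ccc(-n2cc(CCCOS(=O)(=O)c3ccc(C)cc3)nn2)cc1`, which differs from compound 1 as follows: methyl in place of methoxy on an aromatic carbon. This is 4-methoxyphenyl to 4-methylphenyl.

Going by the values given here, the only measured step bearing on it is an at least 1.3-fold higher number from compound 1 to compound 2 (0.12 log units; that floor lies within the scatter). It also replaces the 4-methoxyphenyl group, but gives only a floor, so it sets no size. No shift beyond the scatter is therefore expected in this assay.

The expected step is a 1.1-fold higher number from compound 1 to compound 4 (0.03 log units; within the scatter).

Compound 4 is estimated at 80000 nM, with an expected range from 40000 nM to 150000 nM.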

Compound 4, half-maximal inhibitory concentration: 79900 nM
For compound 4 the middle estimate is 1.0-fold (0.00 log units) above the measured one; low and high end bracket the measured number.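

In this assay, for the compounds shown here, the change from 4-methoxyphenyl to 4-methylphenyl gives the first step of measurable size at this position, a 1.1-fold higher number from compound 1 to compound 4 (0.03 log units; within the scatter), so methyl can stand in for methoxy here with no shift beyond the scatter. The other new step, an at least 1.2-fold lower number from compound 2 to compound 4 (0.09 log units; that floor lies within the scatter), is only a floor and sets no size. It stays a floor because the entry for compound 2 is a limit, not a number: the limit of > 100000 nM in this assay, at which 1 of the 4 values shown sits.

Still open, on these data alone, is whether an amine or a carboxylic acid in this place would move the number beyond the scatter.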